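Carboxy for chloro on the core of compound 2

The compounds below may be only part of what the source reports. "The series", "measured", "known", "first", "only" and "open" are said of these compounds alone.

Measured so far:
compound 1 `CC(O)(C(=O)Nc1ccc(S(=O)(=O)c2ccccc2)c(F)c1)C(F)(F)F` gives 1800 nM in a functional assay (Cavia porcellus) with sulfonylurea receptors; K-ATP channels (Homo sapiens) as the target; on this read-out lower numbers stand for stronger inhibition and higher numbers for weaker inhibition
compound 2 `CC(O)(C(=O)Nc1ccc(S(=O)(=O)c2ccccc2)c(Cl)c1)C(F)(F)F` gives 2200 nM in this assay

Within the data shown here, compound 2 stands highest of the two numbers in this assay, with compound 1 nearest; the step of a 1.2-fold higher number from compound 1 to compound 2 (0.09 log units; within the scatter) is the only measured step. Compound 3 `CC(O)(C(=O)Nc1ccc(S(=O)(=O)c2ccccc2)c(C(=O)O)c1)C(F)(F)F` differs from compound 2 by carboxy in place of chloro on an aromatic carbon. Among the measured compounds shown here, no measured step bears on this change, since the single step known swaps one halogen for another and stays within the scatter. Compound 3 is therefore estimated with wide uncertainty at 4000 nM (range 1000 nM to 16000 nM), and the expected step of a 1.8-fold higher number from compound 2 to compound 3 (0.26 log units; within the scatter) leans toward a higher number.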

Compound 3, half-maximal inhibitory concentration: > 30000 nM
Compound 3: no number, only a limit; the forecaster's own chance of this, stated with the estimate: 15%; middle value at least 7.5-fold (0.87 log units) away from the limit.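

Compound 3 carries a limit and not a number: the limit of > 30000 nM in this assay, at which 1 of the 3 values shown sits. Even so, in this assay carboxy in place of chloro gives an at least 13-fold higher number from compound 2 to compound 3 (1.13 log units; beyond the scatter), and carboxy in place of fluoro gives an at least 16-fold higher number from compound 1 to compound 3 (1.22 log units; beyond the scatter). The two halogens had made this position look indifferent, with a 1.2-fold higher number from compound 1 to compound 2 (0.09 log units; within the scatter), but the carboxy group shows that a change here can cost much of the inhibition.

As far as these compounds go, whether a primary amide, a methyl ester or a nitrile in the same place would bring a comparable loss stays open. From the compounds shown here alone, the true value of compound 3 also stays unknown.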